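The source may report more compounds than this note shows. Statements on the series, on what has been measured and on what is new or still open speak of the compounds shown alone.

Three compounds have so far been measured in a functional assay (muscle tissue) with Cavia porcellus as the target; on this read-out lower numbers stand for stronger inhibition and higher numbers for weaker inhibition:

compound 1, `CC1=NC(C)=C([N+](=O)[O-])C(c2ccccn2)/C1=C(/O)OCCc1ccccc1`, gives 639 nM
compound 2, `CC1=NC(C)=C([N+](=O)[O-])C(c2cccc(C)n2)/C1=C(/O)OCCc1ccccc1`, gives 9980 nM
compound 3, `CC1=NC(C)=C([N+](=O)[O-])C(c2cccc(Cl)n2)/C1=C(/O)OCCc1ccccc1`, gives 1510 nM

Compound 1 stands lowest of the three in this assay; compound 3 comes nearest to it, and compound 2 lies furthest away. Compound 4, `CC1=NC(C)=C([N+](=O)[O-])C(c2ncccc2-c2ccccc2)/C1=C(/O)OCCc1ccccc1`, has not yet been measured. It differs from compound 1 by phenyl in place of hydrogen on an aromatic carbon. Two of the measured steps bear on this change, since each of them also replaces a hydrogen on the same ring of compound 1 with another group: a 16-fold higher number from compound 1 to compound 2 (1.19 log units; beyond the scatter) and a 2.4-fold higher number from compound 1 to compound 3 (0.37 log units; beyond the scatter). For the measured compounds named here, both steps move the number upward, the one to compound 2 much more than the one to compound 3. For compound 4 a step in the same upward direction is therefore expected in this assay, of about the size of the larger of the two, that is a 13-fold higher number from compound 1 to compound 4 (1.10 log units; beyond the scatter). Compound 4 is thus estimated at 8000 nM in this assay, with a range from 2000 nM to 40000 nM.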

Compound 4, half-maximal inhibitory concentration: 3350 nM
The estimate for compound 4 lay 2.4-fold (0.38 log units) above the measured number, and the stated range covers the measured number.
By their numbers in this assay, from the lowest: compound 1; then compound 3; then compound 4; then compound 2.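

At this position, ortho to a large group and two atoms from the ring nitrogen, a phenyl ring costs less than its size might suggest: in this assay the change gives a 5.2-fold higher number from compound 1 to compound 4 (0.72 log units; beyond the scatter). For the compounds shown here, the earlier compounds showed only a methyl and a chloro group on the pyridine-bearing ring's other carbon, so this is the first reading at this carbon and the first for an added aromatic ring. Going by these compounds alone, compound 1, with hydrogen here, remains the lowest of the four, and each of the three groups placed on its ring raises the number, with no compound going against that.

Nothing shown explains the size of this step. The compounds shown leave open whether a methyl, an amine or a carboxylic acid on this same carbon would also raise the number, and by how much.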